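Removing the amino group from compound 3: an open question

The source may report more compounds than this note shows. Statements on the series, on what has been measured and on what is new or still open speak of the compounds shown alone.

Of the compounds shown here, three have been measured in a functional assay on the whole organism for inhibition, with Rattus norvegicus as the target, with stated times of 1 h and 3.5 h, at a dose of 100 mg/kg by the oral route; a lower number here means less inhibition, a higher number more inhibition at the dose given (going by the name of the read-out). Compound 1 `Nc1ncc(-c2ccccc2)c(-c2ccncc2)n1` gives 48%, compound 2 `Cc1ncc2c(n1)CCN(C)C2` gives 45%, and compound 3 `CC(C)(C)c1nc(N)ncc1-c1ccccc1` gives 46%. Compound 3 therefore stands second highest of the three, but its gaps to compound 2 and to compound 1 both lie within the scatter, so the three cannot be ranked against one another. For the measured compounds named here, the one step between measured compounds, tert-butyl in place of pyridin-4-yl on an aromatic carbon, gives a number 2 percentage points lower from compound 1 to compound 3 (within the scatter), a step within the scatter.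

Compound 4 `CC(C)(C)c1ncncc1-c1ccccc1` differs from compound 3 by hydrogen in place of amino on an aromatic carbon. Going by the values given here, no measured pair touches the amino group, so nothing among the measured compounds bears directly on this change; the only measured step, a number 2 percentage points lower from compound 1 to compound 3 (within the scatter), concerns another position and was within the scatter. The estimate for compound 4 in this assay is therefore wide and is expected to be 35%, in the range 10% to 58%. This estimate means an expected step of a number 11 percentage points lower from compound 3 to compound 4 (beyond the scatter), leaning slightly downward but with no firm direction from the data.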

Compound 4, a percentage reported as inhibition, in the whole organism at one dose (the size of the read-out at that dose, not a potency): 48%
Compound 4: the middle estimate sits 13 percentage points below what was measured; measured number inside the range.
By their numbers in this assay, from the lowest: compounds 2, 3, 1 and 4 (each within the scatter of the next).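

For the compounds shown here, compound 4 gives the first reading on the amino group on the aromatic carbon between two ring nitrogen atoms: hydrogen in place of amino gives a number 2 percentage points higher from compound 3 to compound 4 (within the scatter) in this assay at the dose given. With the tert-butyl group kept, the amino group, with its hydrogen-bond donor and acceptor, can therefore be lost from this position without a step beyond the scatter in this read-out. No supporting data are available to account for this result.

From the compounds shown here alone, it remains open whether a hydroxyl or a dimethylamino group at this position would move the number beyond the scatter. Also open, going by these compounds, is whether hydrogen in place of amino would give a similar step with pyridin-4-yl in place of tert-butyl, and since the read-out comes from one dose, the result says nothing about potency.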